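The source may hold more compounds than are shown below. What is called first, only, known or untested is meant among the compounds shown, and "the series" means these compounds.

Of the compounds shown here, three that share one core have been measured in a functional assay on TSU-Pr1 cells for antiproliferative activity against TSU (Homo sapiens), read by sulforhodamine B assay; a lower number here means a stronger inhibitor, a higher number a weaker inhibitor. Compound 1 `CCCCCCCCCCCCCCCCCCNC(=O)[C@H]1CSC(c2c[nH]c3ccccc23)N1` gives 4400 nM. Compound 2 `CCCCCCCCCCCCCCCCCCNC(=O)[C@H]1CSC(c2cccnc2)N1` gives 7800 nM. Compound 3 `CCCCCCCCCCCCCCCCCCNC(=O)[C@H]1CSC(c2ccc([N+](=O)[O-])cc2)N1` gives 15900 nM, the highest of the three numbers. The steps between them, a 1.8-fold higher number from compound 1 to compound 2 (0.25 log units; within the scatter), a 3.6-fold higher number from compound 1 to compound 3 (0.56 log units; beyond the scatter) and a 2.0-fold higher number from compound 2 to compound 3 (0.31 log units; beyond the scatter), each exchange the whole aromatic group that sits on the saturated ring carbon. Compound 4 `CCCCCCCCCCCCCCCCCCNC(=O)[C@H]1CSC(c2ccc(C#N)cc2)N1` keeps the arrangement of compound 3 except for one change: cyano in place of nitro on an aromatic carbon. Among the measured compounds shown here, none of the measured steps swaps one substituent on that six-membered ring for another, so they bear on this step only indirectly: they show that the group on the saturated ring carbon moves the number by a modest amount at most, and that compound 3 stands at the high end. A change this small is expected to leave the number close to where compound 3 stands, and the step of a 1.1-fold lower number from compound 3 to compound 4 (0.06 log units; within the scatter) is what is expected. Compound 4 is estimated at 14000 nM, within 7000 nM to 28000 nM.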

Compound 4, half-maximal inhibitory concentration: > 20000 nM
Compound 4: a limit, no number; the forecaster's own chance of this, stated with the estimate: 10%; at least 1.4-fold (0.15 log units) between middle value and limit.
By their numbers in this assay, from the lowest: compounds 1 and 2 (each within the scatter of the next); then compound 3. At a limit, above all of these: compound 4.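

In this assay, compound 4 gives only a limit, > 20000 nM, and not a number. Among the compounds shown here, this is the first swap of one substituent for another on the six-membered aromatic ring, and cyano in place of nitro brings no gain: an at least 1.2-fold higher number from compound 3 to compound 4 (0.09 log units; that floor lies within the scatter), so the data cannot say whether this change is small or large. The comparisons with the other aromatic groups are firmer, with an at least 2.5-fold higher number from compound 2 to compound 4 (0.40 log units; beyond the scatter) and an at least 4.5-fold higher number from compound 1 to compound 4 (0.65 log units; beyond the scatter), which places 4-cyanophenyl on the weak side of both pyridin-3-yl and 1H-indol-3-yl.

From the compounds shown here alone, how far the true value of compound 4 lies past its limit remains open. Also open, going by these compounds, is whether an amine or a hydroxyl group on that same aromatic carbon would bring the number down.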